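The compounds below may be only part of what the source reports. "The series", "measured", "known", "first", "only" and "open" are said of these compounds alone.

Measured in an ADME assay (liver) for metabolic stability, with Liver microsome (Homo sapiens) as the target, using microsomes; on this read-out higher numbers stand for fast clearance and lower numbers for slow clearance:
- compound 1 `Cc1cnc(NC(=O)c2cc(Oc3cnc(C(=O)N(C)C)cn3)c3cc(C)oc3c2)cn1`: < 8.5 mL/min/kg, a limit
- compound 2 `Cc1cnc(NC(=O)c2cc(Oc3cnc(C(=O)N(C)C)nc3)c3cc(C)oc3c2)cn1`: < 8 mL/min/kg, a limit

Compound 1 stands at a limit and not at a number, < 8.5 mL/min/kg. Compound 2 also gives only a limit, < 8 mL/min/kg. For the measured compounds named here, neither compound has an exact value, and no measured step is available to size a structural change against.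

Compound 3 `Cc1cnc(NC(=O)c2cc(Oc3cnc(C(=O)N4CCCCC4)cn3)c3cc(C)oc3c2)cn1` keeps the core of compound 1 and differs in one place, with piperidin-1-yl in place of dimethylamino on a carbonyl carbon. In this assay, the step of an at least 1.2-fold higher number from compound 1 to compound 3 (0.11 log units; that floor lies within the scatter) is expected to be small and towards faster clearance, and it may stay within the usual scatter. The clearance of compound 3 is estimated at 11 mL/min/kg. The expected range for compound 3 runs from 6 mL/min/kg to 22 mL/min/kg.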

Compound 3, clearance: 18.2 mL/min/kg
Compound 3: the middle estimate sits 1.7-fold (0.22 log units) below what was measured; measured number inside the range.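

In this assay, piperidin-1-yl in place of dimethylamino on a carbonyl carbon gives an at least 2.1-fold higher number from compound 1 to compound 3 (0.33 log units; beyond the scatter), so clearance at this position does respond to the group it carries. For the compounds shown here, compound 3 is also the only one of the three compounds that gives a number and not a limit. The step can be read only as a floor, and its full size stays unknown, because compound 1 stands at a limit: the limit of < 8.5 mL/min/kg in this assay, at which 1 of the 3 values shown sits.

The compounds shown leave open whether the step follows the ring itself or simply the larger group, which pyrrolidin-1-yl, morpholin-4-yl or an open-chain diethylamino on the same carbonyl carbon could separate. They also leave open whether piperidin-1-yl would give a similar step on the core of compound 2.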